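Chloro in Place of Nitro on a Shared Core

The compounds below may be only part of what the source reports. "The series", "measured", "known", "first", "only" and "open" are said of these compounds alone.

Compound 1 `O=C(/C=C\c1cccc(O)c1)N1N=C(c2ccncc2)OC1c1c[nH]c2ccccc12` gives in an ADME assay on HeLa cells (Homo sapiens) for cytotoxicity, read by MTT assay, with a stated time of 72 h (a lower number here means a stronger inhibitor of growth, a higher number a weaker inhibitor of growth), a value that is a limit of the assay, > 30 ug/mL.
Compound 2 `O=C(/C=C\c1cccc([N+](=O)[O-])c1)N1N=C(c2ccncc2)OC1c1c[nH]c2ccccc12` gives in this assay a value that is likewise a limit, > 30 ug/mL.

Compound 2 therefore stands at the limit of this assay, and no number is known for it; (the limit of > 30 ug/mL in this assay, at which 2 of the 2 values shown sit). Within the data shown here, the only measured step, a step that the two limits leave unreadable from compound 1 to compound 2, runs between two limits and so has no readable size. Compound 3 `O=C(/C=C\c1cccc(Cl)c1)N1N=C(c2ccncc2)OC1c1c[nH]c2ccccc12` differs from compound 2 by chloro in place of nitro on an aromatic carbon. No measured step speaks directly to this exchange, and the one step shown, a step that the two limits leave unreadable from compound 1 to compound 2, offers no size to carry over. The step that the limit leaves unreadable from compound 2 to compound 3 is expected to show nothing beyond the scatter, with compound 3 most likely again reported only as a limit. Compound 3 is estimated in this assay at 45 ug/mL, with a range from 20 ug/mL to 100 ug/mL.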

Compound 3, concentration for 50% growth inhibition: > 30 ug/mL
Compound 3 was reported as a limit; the forecaster's own chance of this, stated with the estimate: 75%; the middle value does not contradict the limit.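

In this assay compound 3 gives > 30 ug/mL, which is a limit and not a number, so no new step can be read among compound 1, compound 2 and compound 3: the limit of > 30 ug/mL in this assay, at which 3 of the 3 values shown sit.

The compounds shown leave open how the hydroxy, nitro and chloro groups compare in this assay.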